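Replacing pyridin-4-yl with phenyl in compound 2

The source may report more compounds than this note shows. Statements on the series, on what has been measured and on what is new or still open speak of the compounds shown alone.

Compound 1 `COc1cc(CCc2ccccn2)cc(OC)c1O`: 4840 nM
Compound 2 `COc1cc(CCc2ccncc2)cc(OC)c1O`: 2170 nM

In a functional assay on HepG2 cells (Homo sapiens) for antiproliferative activity, read by MTT assay, with a stated time of 72 h (on this read-out lower numbers stand for stronger inhibition and higher numbers for weaker inhibition), compound 2 gives 2170 nM, the lower of the two numbers. Compound 3 `COc1cc(CCc2ccccc2)cc(OC)c1O` differs from it in one place: phenyl in place of pyridin-4-yl on a saturated chain carbon, two bonds along the chain from an aromatic carbon. For the measured compounds named here, only one measured step bears on this change, the swap of pyridin-2-yl for pyridin-4-yl, a 2.2-fold lower number from compound 1 to compound 2 (0.35 log units; beyond the scatter). Going by the values given here, no measured compound yet shows the effect of a ring of carbon only, so the direction is uncertain. A step no larger than that one is expected, leaning towards a higher number in this assay, a 1.8-fold higher number from compound 2 to compound 3 (0.27 log units; within the scatter). The estimate for compound 3 is 4000 nM, with an expected range of 1300 nM to 12000 nM.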

Compound 3, half-maximal inhibitory concentration: 7830 nM
The estimate for compound 3 lay 2.0-fold (0.29 log units) below the measured number; low and high end bracket the measured number.
By their numbers in this assay, from the lowest: compound 2; then compounds 1 and 3 (each within the scatter of the next).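

In this assay, phenyl at this position separates clearly from pyridin-4-yl, with a 3.6-fold higher number from compound 2 to compound 3 (0.56 log units; beyond the scatter), so a ring nitrogen counts here in one placement but not in every placement. Set against pyridin-2-yl, the same phenyl ring shows no real difference, with a 1.6-fold higher number from compound 1 to compound 3 (0.21 log units; within the scatter). Nothing available gives a reason for this. On these data alone, it remains open whether pyridin-3-yl would read like pyridin-4-yl or like phenyl, and how pyridin-4-yl would fare on a longer chain.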